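The compounds below may be only part of what the source reports. "The series", "measured", "known", "first", "only" and "open" are said of these compounds alone.

Measured compounds in a functional assay on DU-145 cells (Homo sapiens) for cytotoxicity, read by MTT assay, with a stated time of 72 h; a higher number here means a weaker inhibitor, a lower number a stronger inhibitor:

- compound 1, `COc1ccc(C(=O)c2cc(OC)c(OC)c(OC)c2)cc1NC(=O)/C=C/c1cc(OC)c(OC)c(OC)c1`: 6300 nM
- compound 2, `COc1ccc(C(=O)c2cc(OC)c(OC)c(OC)c2)cc1NC(=O)/C=C/c1ccc(OC)c(OC)c1`: 10200 nM
- compound 3, `COc1cc(C(=O)c2cc(OC)c(OC)c(OC)c2)cc(NC(=O)/C=C/c2cc(OC)c(OC)c(OC)c2)c1OC`: 6600 nM

Compound 3 stands second highest of the three numbers. Its nearest neighbour is compound 1, and the two numbers lie within the scatter of each other; compound 2 is furthest away, yet still within the scatter.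

Compound 4, `COc1ccc(/C=C/C(=O)Nc2cc(C(=O)c3cc(OC)c(OC)c(OC)c3)cc(OC)c2OC)cc1OC`, differs from compound 3 by hydrogen in place of methoxy on an aromatic carbon. Among the measured compounds shown here, the one measured step that bears on this change is the one from compound 1 to compound 2, where the same trimming of the 3,4,5-trimethoxyphenyl to a 3,4-dimethoxyphenyl on the core of compound 1 gave a 1.6-fold higher number from compound 1 to compound 2 (0.21 log units; within the scatter). On that basis no step beyond the scatter is expected in this assay for compound 4, at most a small drift toward a higher number, as the move from compound 1 to compound 2 hinted.

Compound 4 is therefore estimated at about 9500 nM, with a range from 5000 nM to 18000 nM. That estimate implies a step of a 1.4-fold higher number from compound 3 to compound 4 (0.16 log units; within the scatter), which is expected to stay within the usual scatter.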

Compound 4, half-maximal inhibitory concentration: 7800 nM
For compound 4 the middle estimate is 1.2-fold (0.09 log units) above the measured one, and the stated range covers the measured number.
By their numbers in this assay, from the lowest: compounds 1, 3, 4 and 2 (each within the scatter of the next).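

In this assay, trimming the 3,4,5-trimethoxyphenyl to a 3,4-dimethoxyphenyl now gives a 1.2-fold higher number from compound 3 to compound 4 (0.07 log units; within the scatter), so this change has been read on a second core and stays within the scatter on both: the same change on two cores in this assay, a 1.6-fold higher number (0.21 log units; within the scatter) from compound 1 to compound 2 and a 1.2-fold higher number (0.07 log units; within the scatter) from compound 3 to compound 4, 1.4-fold (0.14 log units) apart, within the scatter of two such steps. The other change in this set of compounds, methoxy in place of hydrogen on an aromatic carbon elsewhere in the shared core, gives a 1.3-fold lower number from compound 2 to compound 4 (0.12 log units; within the scatter), and it too now stands on two cores: the same change on two cores in this assay, a 1.0-fold higher number (0.02 log units; within the scatter) from compound 1 to compound 3 and a 1.3-fold lower number (0.12 log units; within the scatter) from compound 2 to compound 4, 1.4-fold (0.14 log units) apart, within the scatter of two such steps. Across these four compounds, then, neither change moves the number beyond the scatter, whichever form the other place carries.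

At this position the compounds shown carry only methoxy or hydrogen. As far as these compounds go, what a hydroxyl, an amine, a carboxylic acid or a longer chain such as ethoxy would give there remains open.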